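Carbamate Exchanged for a Fluorinated Benzoate Ester

The source may report more compounds than this note shows. Statements on the series, on what has been measured and on what is new or still open speak of the compounds shown alone.

Compound 1 `CC(=O)O[C@H]1CC[C@]2(C)[C@H](CC[C@@](C)(O)[C@H]2CC[C@@H]2C(C)=CC[C@@H]3C(C)=CC[C@@H]3C2(C)C)OC1(C)C` and compound 2 `CC1=CC[C@H]2[C@H](CC[C@]2(C)O)C(C)(C)[C@@H]1CC[C@H]1[C@]2(C)CC[C@H](OC(=O)NCc3ccccc3)C(C)(C)O[C@H]2CC[C@@]1(C)O` are two related compounds with a shared core. In a functional assay on MDA-MB-231 cells (Homo sapiens) for antiproliferative activity, read by MTT assay, with a stated time of 72 h (a higher number here means a weaker inhibitor, a lower number a stronger inhibitor), compound 1 gives 39200 nM and compound 2 gives 40300 nM. These two numbers lie within the usual scatter of each other, so neither compound can be called the stronger inhibitor. Compound 3 `CC1=CC[C@H]2[C@H](CC[C@]2(C)O)C(C)(C)[C@@H]1CC[C@H]1[C@]2(C)CC[C@H](OC(=O)c3ccccc3F)C(C)(C)O[C@H]2CC[C@@]1(C)O` keeps the core of compound 2 and carries 2-fluorophenyl in place of benzylamino on a carbonyl carbon. Among the compounds with values here, no measured pair shows what such an exchange does here, so no shift beyond the scatter is expected. The step from compound 2 to compound 3 is estimated at a 1.2-fold lower number from compound 2 to compound 3 (0.06 log units; within the scatter). Compound 3 is expected to give 35000 nM, between 15000 nM and 80000 nM.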

Compound 3, half-maximal inhibitory concentration: 28700 nM
Estimate against measurement, compound 3: 1.2-fold (0.09 log units) above; measured number inside the range.
By their numbers in this assay, from the lowest: compounds 3, 1 and 2 (each within the scatter of the next).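

In this assay, putting 2-fluorophenyl in place of benzylamino on the carbonyl carbon gives a 1.4-fold lower number from compound 2 to compound 3 (0.15 log units; within the scatter) and so leaves the two compounds indistinguishable. This position therefore accepts an ester as well as a carbamate, and losing the nitrogen with its hydrogen-bond donor brings no shift that stands out from the scatter. Nothing at hand explains this result.

The share of the fluorine cannot be judged without plain phenyl on the same carbonyl carbon. On these data alone, what an amine or a carboxylic acid at this position would do also remains open.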